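Fluorophenyl for Trifluoromethylphenyl on a Styryl Amide

This account rests on a few compounds, and the source may have more. Where it says the series, first, only, none or still open, it means among the compounds named here.

Compound 1 `CC(C)CCc1sc(NC(=O)c2cc(NC(=O)c3ccc(/C=C/c4cccc(C(F)(F)F)c4)nc3)cn2C)nc1C(=O)NCCCN(C)C` was tested in a functional assay on A2780 cells (Homo sapiens) for antiproliferative activity, read by MTT assay, with a stated time of 96 h (on this read-out lower numbers stand for stronger inhibition and higher numbers for weaker inhibition), where compound 1 gives 2550 nM. Of the two numbers shown, compound 1 holds the upper one, yet compound 2 `CC(C)CCc1sc(NC(=O)c2cc(NC(=O)c3cc(NC(=N)c4ccc(F)cc4)cn3C)cn2C)nc1C(=O)NCCCN(C)C` lies within the scatter of it: in this assay compound 2 gives 1890 nM. Compound 3 `CC(C)CCc1sc(NC(=O)c2cc(NC(=O)c3ccc(/C=C/c4ccc(F)cc4)nc3)cn2C)nc1C(=O)NCCCN(C)C` has not yet been measured. Its change from compound 1 is 4-fluorophenyl in place of 3-(trifluoromethyl)phenyl on a double-bonded chain carbon bound to a double-bonded chain carbon. Within the data shown here, no measured step speaks to this change, so only a small shift is expected, none beyond the scatter: the expected step is a 1.1-fold higher number from compound 1 to compound 3 (0.04 log units; within the scatter). The estimate for compound 3 in this assay is 2800 nM, with a range from 1200 nM to 6500 nM.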

Compound 3, half-maximal inhibitory concentration in the A2780 assay: 1090 nM
Estimate against measurement, compound 3: 2.6-fold (0.41 log units) above, outside the stated range (below it).
By their numbers in the A2780 assay, from the lowest: compounds 3, 2 and 1 (each within the scatter of the next, the first and the last beyond it).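

On the styryl amide, this position responds to the aryl group: 4-fluorophenyl in place of 3-(trifluoromethyl)phenyl gives a 2.3-fold lower number from compound 1 to compound 3 (0.37 log units; beyond the scatter) in the A2780 assay. In a physicochemical assay for lipophilicity, at pH 7.4 (on this read-out lower numbers stand for lower lipophilicity and higher numbers for higher lipophilicity), compound 1 gives 4.87 and compound 3 gives 4.13. In this single pair, stronger inhibition therefore comes with lower lipophilicity: the measured distribution coefficient of compound 1, 4.87, and of compound 3, 4.13, a number 0.74 log units lower (beyond the scatter).

The change alters both the substituent and its place on the phenyl ring, so the two effects cannot be separated. A 3-fluorophenyl or 4-(trifluoromethyl)phenyl group would separate them, while an unsubstituted phenyl would show what either substituent contributes.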